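The source may report more compounds than this note shows. Statements on the series, on what has been measured and on what is new or still open speak of the compounds shown alone.

Three compounds in this small set share a core carrying a sulfamate group, and differ only in the amine attached to the aromatic ring of the amide. Compound 1 `NS(=O)(=O)Oc1ccc2c(c1)CN(C(=O)c1ccc(N3CCCCC3)cc1)CC2` carries a piperidin-1-yl group and gives 38.3% in an assay on HEK293 cells for inhibition of Steryl-sulfatase (Homo sapiens), tested at 1 uM; on this read-out higher numbers stand for a stronger effect at the one concentration tested and lower numbers for a weaker effect. Compound 2 `CCN(Cc1ccccn1)c1ccc(C(=O)N2CCc3ccc(OS(N)(=O)=O)cc3C2)cc1` carries an ethyl((pyridin-2-yl)methyl)amino group instead; in this assay compound 2 gives 87.7%. Compound 3 `NS(=O)(=O)Oc1ccc2c(c1)CN(C(=O)c1cccc(N(Cc3ccccc3)Cc3ccco3)c1)CC2` gives 90.5% in this assay. Among these three numbers compound 2 stands second highest, with compound 3 close by within the scatter and compound 1 far below it.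

Among the measured compounds shown here, the only measured step that bears on the change now considered is a number 49.4 percentage points higher from compound 1 to compound 2 (beyond the scatter), a large rise on exchanging a cyclic amine for an open-chain one bearing a ring in its side chain.

Compound 4 `CCCN(CCC)c1ccc(C(=O)N2CCc3ccc(OS(N)(=O)=O)cc3C2)cc1` has not yet been measured. Its difference from compound 2 is dipropylamino in place of ethyl((pyridin-2-yl)methyl)amino on an aromatic carbon. For the measured compounds named here, the dipropylamino group keeps the open-chain character of compound 2 but loses the ring counted above, so no measured step mirrors this change exactly. Some loss from compound 2 is expected, of uncertain size, and the estimated step is a number 22.7 percentage points lower from compound 2 to compound 4 (beyond the scatter). For compound 4 the expected value in this assay is 65%, within a range from 35% to 90%.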

Compound 4, a percentage reported as inhibition, at one concentration (the size of the read-out at that concentration, not a potency): 84.7%
Compound 4: middle estimate off by 19.7 percentage points, on the low side, within the range that was stated.
By their numbers in this assay, from the lowest: compound 1; then compounds 4, 2 and 3 (each within the scatter of the next).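

Exchanging the ethyl((pyridin-2-yl)methyl)amino group for dipropylamino removes the six-membered aromatic ring from the side chain, yet in this assay the change gives a number 3 percentage points lower from compound 2 to compound 4 (within the scatter) and so shows no real change at this position. The ring in the side chain is therefore not needed for a high read-out at this concentration, something that the rise from compound 1 to compound 2 alone could not show. The other new step, a number 46.4 percentage points higher from compound 1 to compound 4 (beyond the scatter), shows that an open-chain amine with no ring at all also stands far above piperidin-1-yl, so among compounds 1, 2 and 4 the large gap separates the cyclic amine from the two open-chain amines, whether or not their side chains carry a ring.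

Nothing measured here explains why piperidin-1-yl falls so far behind these two open-chain amines. From the compounds shown here alone, it also remains open whether a shorter open-chain amine such as dimethylamino would hold the read-out as dipropylamino does, or whether another cyclic amine such as pyrrolidin-1-yl or morpholin-4-yl would fall as low as piperidin-1-yl.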